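Propargylamine aminoindanes with thioether side chains: bromophenyl two-carbon homologue

A few compounds are considered here, and "the series" means these few. Any claim that something is new, unique, unknown or untested is made for them only; others in the source may bear on it.

Compound 1 `C#CCNC1CCc2c(SCCc3cccc(Cl)c3)cccc21` carries a two-carbon chain from the sulfur to a 3-chlorophenyl group; in an ADME assay on isolated protein for inhibition of Amine oxidase [flavin-containing] B (Homo sapiens) (a higher number here means a weaker inhibitor, a lower number a stronger inhibitor), compound 1 gives "not determined" (no result reported), so no number places it within the series. Compound 2 `C#CCNC1CCc2c(SCc3cccc(Br)c3)cccc21` gives a limit of the assay in this assay, > 100000 nM; this is the limit of > 100000 nM in this assay, at which 1 of the 3 values shown sits. Compound 3 `C#CCNC1CCc2c(SCc3ccc(OC)cc3)cccc21` gives 3960 nM in this assay. Compound 4 `C#CCNC1CCc2c(SCCc3ccc(Br)cc3)cccc21` differs from compound 1 by 4-bromophenyl in place of 3-chlorophenyl on a saturated chain carbon, two bonds along the chain from a sulfur. Going by the values given here, no measured step anchors this change, and the halophenyl compound 2 sits at the limit while the methoxyphenyl compound 3 shows a number, so a wide range is expected in this assay for compound 4, with a real chance of another limit. Compound 4 is estimated at 25000 nM, expected between 3000 nM and 150000 nM.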

Compound 4, half-maximal inhibitory concentration: 1250 nM
Compound 4: middle estimate off by 20-fold (1.30 log units), on the high side; measured number below the stated range.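

No step can be read between compound 1 and compound 4, as compound 1 has no number in this assay. Nothing at hand bears on this result. The compounds shown leave open how chain length and the substituent on the phenyl group each act alone.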